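The source may report more compounds than this note shows. Statements on the series, on what has been measured and on what is new or still open speak of the compounds shown alone.

Compound 1, `O=C1C=C(NC2CCCC2)C(=O)c2c1nc1n2[C@H]2OC[C@@H](O)[C@H]2OC1`, is the point of departure. In a functional assay on ECa-109 cells for inhibition, with ECa-109 cell line (Homo sapiens) as the target, read by sulforhodamine B assay (a higher number here means a weaker inhibitor, a lower number a stronger inhibitor), compound 1 gives > 16000 nM, which is a limit of the assay rather than a number. Among the three measured values it stands at the weak end, since (the limit of > 16000 nM in this assay, at which 1 of the 3 values shown sits). Compound 2, `CCOc1ccccc1NC1=CC(=O)c2nc3n(c2C1=O)[C@H]1OC[C@@H](O)[C@H]1OC3`, gives 4630 nM in this assay, and compound 3, `O=C1C(Nc2cccc(Cl)c2)=CC(=O)c2c1nc1n2[C@H]2OC[C@@H](O)[C@H]2OC1`, gives 3080 nM. Among the compounds with values here, the one measured step that starts from compound 1 is an at least 3.4-fold lower number from compound 1 to compound 2 (0.53 log units; beyond the scatter).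

Compound 4, `O=C1C=C(N2CCCC2)C(=O)c2c1nc1n2[C@H]2OC[C@@H](O)[C@H]2OC1`, is not yet measured. It differs from compound 1 by pyrrolidin-1-yl in place of cyclopentylamino on a double-bonded ring carbon; the cyclopentylamino group gives way to pyrrolidin-1-yl on a double-bonded ring carbon, and the one hydrogen-bond donor leaves with it. Within the data shown here, none of the measured steps concerns this change: the step from compound 1 to compound 2 swaps the ring on the amine nitrogen but keeps the hydrogen-bond donor, whereas here that donor is lost. The step from compound 1 to compound 2 thus offers no direction for compound 4, and compound 3 shares no single change with it. Compound 4 is therefore expected to remain near the weak end, with the step from compound 1 estimated as a step that the limit leaves unreadable from compound 1 to compound 4. For compound 4 the value in this assay is estimated at 20000 nM, within 6000 nM to 60000 nM, and a limit rather than a number is quite possible.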

Compound 4, half-maximal inhibitory concentration: > 16000 nM
Compound 4 was reported as a limit; the forecaster's own chance of this, stated with the estimate: 60%; the middle value lies beyond the limit too.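

Within the data shown here, compound 1 and compound 4 are both reported only as a limit of this assay and not as a number, so no step between the two can be read. The compounds shown leave open whether pyrrolidin-1-yl in place of cyclopentylamino, with the hydrogen-bond donor gone, changes the inhibition at all, and in which direction.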